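Swapping the pyridine amide side chain on the shared core

A few compounds are considered here, and "the series" means these few. Any claim that something is new, unique, unknown or untested is made for them only; others in the source may bear on it.

In a functional assay (aorta) with Rattus norvegicus as the target (on this read-out lower numbers stand for an effect already at smaller amounts and higher numbers for an effect only at larger amounts of compound), compound 1 `COc1ccc(-c2nc(/N=C(\N)NC(C)C)sc2-c2ccc(OC)cc2)cc1` gives 9.1 uM and compound 2 `COc1ccc(-c2nc(CNC(=O)c3cccnc3)sc2-c2ccc(OC)cc2)cc1` gives 8.2 uM and thus stands level with compound 1 within the scatter. The change to compound 3 `COc1ccc(-c2nc(C(=O)N=C(N)N)sc2-c2ccc(OC)cc2)cc1` is a group of 6 heavy atoms (2 carbon, 3 nitrogen, 1 oxygen; no ring) in place of a group of 10 heavy atoms (7 carbon, 2 nitrogen, 1 oxygen; one six-membered aromatic ring with 1 hetero atom), on an aromatic carbon and both 4-methoxyphenyl groups stay in place. Among the compounds with values here, the one measured step at this place (a 1.1-fold lower number from compound 1 to compound 2 (0.05 log units; within the scatter)) exchanged two quite different groups and stayed within the scatter. This single step is thin evidence, but it gives no reason to expect a shift in either direction. In this assay the expected change is therefore none beyond the scatter (a 1.0-fold higher number from compound 2 to compound 3 (0.02 log units; within the scatter)). For compound 3 the estimate is 8.5 uM (expected range 3 uM to 25 uM).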

Compound 3, concentration for half-maximal effect: > 100 uM
Compound 3 ended at the assay's limit; the forecaster's own chance of this, stated with the estimate: 10%; at least 11-fold (1.07 log units) between middle value and limit.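

In this assay this position proves sensitive to the group it carries, a point the level pair of compound 1 and compound 2 did not show: an at least 12-fold higher number from compound 2 to compound 3 (1.08 log units; beyond the scatter), and an at least 10-fold higher number from compound 1 to compound 3 (1.04 log units; beyond the scatter). Having no ring in the group does not decide the outcome, as compound 1 has none either. For compound 3, > 100 uM is a limit and not a number, so both steps give only a minimum size: the limit of > 100 uM in this assay, at which 1 of the 3 values shown sits.

Open, from the compounds shown here alone, is which part of the entering group goes with the higher number. A carboxylic acid, a simple amine or a longer chain at this position could help to separate these parts.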